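The source may report more compounds than this note shows. Statements on the series, on what has been measured and on what is new or still open speak of the compounds shown alone.

Measured so far:
compound 1 `NC(=O)C1CCN(c2cc3c(cc2F)c(=O)c(C(=O)NCc2ccc(Cl)cc2Cl)cn3C2CC2)CC1` — > 20000 nM
compound 2 `CCOC(=O)N1CCN(c2cc3c(cc2F)c(=O)c(C(=O)NCc2ccc(Cl)cc2Cl)cn3CC)CC1` — > 20000 nM

In an ADME assay on Vero cells (Chlorocebus sabaeus) for cytotoxicity, read by MTT assay, with a stated time of 16 h (a higher number here means that more compound is tolerated, a lower number that less compound is tolerated), compound 2 gives > 20000 nM, which is a limit of the assay and not a number. Compound 1 in this assay likewise gives > 20000 nM, again only a limit. Among the compounds with values here, both measured values thus sit at the limit of > 20000 nM in this assay, at which 2 of the 2 values shown sit, so no numerical half-maximal cytotoxic concentration exists in the set and no step between measured compounds can be drawn.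

Compound 3 `CCOC(=O)N1CCN(c2cc3c(cc2F)c(=O)c(C(=O)NCc2ccc(Cl)cc2Cl)cn3C2CC2)CC1` is not yet measured. It differs from compound 2 in one place: cyclopropyl in place of ethyl on an aromatic nitrogen of a six-membered aromatic ring with one nitrogen, part of a fused system of two rings. Compound 1 already carries cyclopropyl on that nitrogen, with a different group elsewhere, and sits at the same limit as compound 2.

With both measured compounds at the limit, the expected step is a step that the limit leaves unreadable from compound 2 to compound 3, nothing beyond the usual scatter. Compound 3 is expected to give 25000 nM in this assay, with a range from 12000 nM to 50000 nM, most probably reported again only as a limit.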

Compound 3, half-maximal cytotoxic concentration: 15000 nM
The estimate for compound 3 lay 1.7-fold (0.22 log units) above the measured number; low and high end bracket the measured number.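

In this assay, within the data shown here, compound 3 gives the first actual number, so the position on the aromatic nitrogen can now be read from one side rather than from limits alone. Cyclopropyl in place of ethyl on that nitrogen gives an at least 1.3-fold lower number from compound 2 to compound 3 (0.12 log units; that floor lies within the scatter), and with cyclopropyl held in place, 4-(ethoxycarbonyl)piperazin-1-yl in place of 4-carbamoylpiperidin-1-yl on an aromatic carbon gives an at least 1.3-fold lower number from compound 1 to compound 3 (0.12 log units; that floor lies within the scatter). Both steps are floors within the scatter, so neither change is established as lowering the number, and each remains open upward, since the other two compounds are reported only at a limit of the assay: the limit of > 20000 nM in this assay, at which 2 of the 3 values shown sit.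

Still open, on these data alone, is whether a cyclobutyl group or a longer chain such as n-butyl on the aromatic nitrogen would give a step beyond the scatter. Also open, as far as these compounds go, is how a carboxylic acid or a free amine in place of the ethoxycarbonyl group on the piperazine would read in this assay.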